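A Chain Gives Way to a Bromopyridine Ring

The source may hold more compounds than are shown below. What is called first, only, known or untested is meant among the compounds shown, and "the series" means these compounds.

Measured so far in an assay on CHO-K1 cells for displacement of a labelled ligand from adenosine receptor A1 (Homo sapiens), read by scintillation counting, with a stated time of 60 min; on this read-out higher numbers stand for weaker inhibition and lower numbers for stronger inhibition:
Compound 1 `Nc1nc(N/N=C/c2ccc3ncccc3c2)nc2c1ncn2[C@@H]1O[C@H](CO)[C@@H](O)[C@H]1O` gives 9.8 nM in this assay.
Compound 2 `CCOc1cc(/C=N/Nc2nc(N)c3ncn([C@@H]4O[C@H](CO)[C@@H](O)[C@H]4O)c3n2)ccc1O` gives 6940 nM.
Compound 3 `CSCC/C=N/Nc1nc(N)c2ncn([C@@H]3O[C@H](CO)[C@@H](O)[C@H]3O)c2n1` gives > 10000 nM, which is a limit of the assay and not a number.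

Compound 3 therefore stands at the edge of what this assay can report: the limit of > 10000 nM in this assay, at which 1 of the 3 values shown sits. Its position relative to compound 2 is only loosely fixed, since an at least 1.4-fold higher number from compound 2 to compound 3 (0.15 log units; that floor lies within the scatter).

The step to compound 4 `Nc1nc(N/N=C/c2ccc(Br)cn2)nc2c1ncn2[C@@H]1O[C@H](CO)[C@@H](O)[C@H]1O` is this: 5-bromopyridin-2-yl in place of 2-(methylsulfanyl)ethyl on a carbon with a double bond to nitrogen. The measured steps that bear on it all concern the same carbon with a double bond to nitrogen. Going from the quinolin-6-yl group to the chain, an at least 1000-fold higher number from compound 1 to compound 3 (3.00 log units; beyond the scatter); going from that group to the phenyl with ethoxy and hydroxy substituents, a 710-fold higher number from compound 1 to compound 2 (2.85 log units; beyond the scatter). Both show that an aromatic ring bearing a ring nitrogen at this carbon is associated with far stronger inhibition than the chain or the substituted phenyl. The 5-bromopyridin-2-yl group brings back a six-membered aromatic ring with a ring nitrogen, so a large step toward stronger inhibition in this assay is expected, though compound 4 need not reach compound 1.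

Compound 4 is expected to give 200 nM (range 20 nM to 3000 nM), a step of an at least 50-fold lower number from compound 3 to compound 4 (1.69 log units; beyond the scatter).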

Compound 4, inhibition constant: 4.7 nM
Compound 4: the middle estimate sits 43-fold (1.63 log units) above what was measured; measured number outside the range, below it.
By their numbers in this assay, from the lowest: compound 4; then compound 1; then compound 2. At a limit, above all of these: compound 3.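

Compound 3 holds a limit of the assay, not a number, in this assay: the limit of > 10000 nM in this assay, at which 1 of the 4 values shown sits. Replacing its 2-(methylsulfanyl)ethyl with 5-bromopyridin-2-yl gives an at least 2100-fold lower number from compound 3 to compound 4 (3.32 log units; beyond the scatter), a step that is only a floor, and the same group in place of 3-ethoxy-4-hydroxyphenyl gives a 1500-fold lower number from compound 2 to compound 4 (3.17 log units; beyond the scatter). What is new is that quinolin-6-yl is not required for strong inhibition at this carbon with a double bond to nitrogen: a single six-membered aromatic ring with one ring nitrogen and a bromine does the job, and the comparison of the two groups gives a 2.1-fold lower number from compound 1 to compound 4 (0.32 log units; beyond the scatter), a modest step just beyond the scatter in favour of the bromopyridine.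

Which part of 5-bromopyridin-2-yl matters stays open, and a pyridin-2-yl without the bromine or a 4-bromophenyl without the ring nitrogen would separate the two. Equally open, as far as these compounds go, is whether a plain phenyl, with neither ethoxy nor hydroxy, would sit near compound 4 or near compound 2.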